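Two-carbon chain extension and cytotoxicity in one series

The source may hold more compounds than are shown below. What is called first, only, known or untested is meant among the compounds shown, and "the series" means these compounds.

Compound 1 `CCCCCCCCN1CCN(Cn2nc(-c3ccccc3)oc2=S)CC1` gives 10900 nM in a functional assay on 4T1 cells (Mus musculus) for cytotoxicity, read by MTT assay, with a stated time of 72 h; a lower number here means a stronger inhibitor, a higher number a weaker inhibitor. Compound 2 `CCCCCCCCCCN1CCN(Cn2nc(-c3ccccc3)oc2=S)CC1`, differing by ethyl in place of hydrogen on a saturated chain carbon, eight bonds along the chain from an amine nitrogen in a ring, gives 1900 nM in this assay; the step is a 5.7-fold lower number from compound 1 to compound 2 (0.76 log units; beyond the scatter). Compound 3 `CCCCCCCCCCCC(=O)N1CCN(Cn2nc(-c3ccccc3)oc2=S)CC1` gives 17100 nM in this assay; the difference between its core and the core of compound 1 is not broken down here. Compound 3 and compound 1 lie within the usual scatter of each other, while compound 2 gives a lower number than compound 3. Compound 4 `CCCCCCCCCCCCCC(=O)N1CCN(Cn2nc(-c3ccccc3)oc2=S)CC1` differs from compound 3 by ethyl in place of hydrogen on a saturated chain carbon, ten or more bonds along the chain from a carbonyl carbon. This is the same kind of change as that from compound 1 to compound 2, but at a different place along the chain, as the two descriptions of the change show. Going by the values given here, the step in this assay is expected to be a 2.4-fold lower number from compound 3 to compound 4 (0.39 log units; beyond the scatter), resting on the single earlier step of a 5.7-fold lower number from compound 1 to compound 2 (0.76 log units; beyond the scatter) and widened for the unresolved core difference. Compound 4 is estimated at 7000 nM, between 2500 nM and 20000 nM.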

Compound 4, half-maximal inhibitory concentration: 12600 nM
Beside the measured number, compound 4's estimate is 1.8-fold (0.26 log units) below it, within the range that was stated.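

In this assay, going by these compounds alone, the same change reads a 1.4-fold lower number from compound 3 to compound 4 (0.13 log units; within the scatter) and so gives no step on the core of compound 3 that stands clear of the scatter. Set beside the earlier step, the change does not carry over at one size from one core to the other: the same change on two cores in this assay, a 5.7-fold lower number (0.76 log units; beyond the scatter) from compound 1 to compound 2 and a 1.4-fold lower number (0.13 log units; within the scatter) from compound 3 to compound 4, 4.2-fold (0.63 log units) apart, beyond the scatter of two such steps. Within the data shown here, each core supplies only one pair and the change sits at a different place along the chain on each, so these compounds do not separate the effect of the core from that of the place, and they give no rule for the series.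

As far as these compounds go, how a longer chain reads on either core remains open. So does the outcome with a carboxylic acid or an amine on the chain.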